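Compound 3 and its aryl exchange

This account rests on a few compounds, and the source may have more. Where it says the series, first, only, none or still open, it means among the compounds named here.

In a functional assay on A549 cells (Homo sapiens) for cytotoxicity, read by MTT assay, with a stated time of 48 h (a lower number here means a stronger inhibitor, a higher number a weaker inhibitor), compound 1 `COc1cc(-n2c(-c3ccc(O)cc3)c[nH]c2=O)cc(OC)c1OC` gives > 50000 nM as a limit and not a number. Compound 2 `COc1ccc(-c2c[nH]c(=O)n2-c2cc(OC)c(OC)c(OC)c2)cc1OC` likewise gives > 50000 nM as a limit. Going by the values given here, compound 3 `COc1cc(NC(=O)n2cc(-c3ccc(O)cc3)n(-c3cc(OC)c(OC)c(OC)c3)c2=O)cc(OC)c1OC` gives 2500 nM as the only true number so far. Compound 4 `COc1ccc(-c2cn(C(=O)Nc3cc(OC)c(OC)c(OC)c3)c(=O)n2-c2cc(OC)c(OC)c(OC)c2)cc1N` carries 3-amino-4-methoxyphenyl in place of 4-hydroxyphenyl on an aromatic carbon, and the change counts as 3-amino-4-methoxyphenyl in place of 4-hydroxyphenyl on an aromatic carbon in full. Among the compounds with values here, no measured pair isolates this exchange, so the direction is a judgement only. In this assay the expected outcome is the estimated step of a 5.0-fold lower number from compound 3 to compound 4 (0.70 log units; beyond the scatter) towards stronger inhibition. For compound 4 the estimated value is 500 nM within an expected range of 40 nM to 5000 nM as a working figure.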

Compound 4, half-maximal inhibitory concentration: 11100 nM
The estimate for compound 4 lay 22-fold (1.35 log units) below the measured number; the measured number lies above the stated range.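

At the aromatic carbon of the five-membered ring, this assay now gives a readable step: 3-amino-4-methoxyphenyl in place of 4-hydroxyphenyl gives a 4.4-fold higher number from compound 3 to compound 4 (0.65 log units; beyond the scatter), towards weaker inhibition. Compound 1 and compound 2 also differ at this carbon, but each gives only a limit, so that pair offers no size or direction for an aryl exchange: the limit of > 50000 nM in this assay, at which 2 of the 4 values shown sit.

This single step does not separate the contribution of the amine from that of the methoxy group. As far as these compounds go, how a carboxylic acid on this aryl ring would read also stays open.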